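A few compounds are considered here, and "the series" means these few. Any claim that something is new, unique, unknown or untested is made for them only; others in the source may bear on it.

Of the compounds shown here, two built on the same core have been tested in a functional assay on NCI-H1975 cells (Homo sapiens) for antiproliferative activity, read by MTT assay, with a stated time of 72 h; a higher number here means a weaker inhibitor, a lower number a stronger inhibitor. Compound 1, `COc1cc2ncnc(Nc3ccc(Cl)cc3)c2cc1OCCCCC(=O)Nc1ccc(S(N)(=O)=O)cc1`, gives 31800 nM. Compound 2, `COc1cc2ncnc(Nc3cccc(C)c3)c2cc1OCCCCC(=O)Nc1ccc(S(N)(=O)=O)cc1`, gives 32100 nM. The only difference between them is the group carried on the nitrogen attached to the aromatic ring of the core, and the step of a 1.0-fold higher number from compound 1 to compound 2 (0.00 log units; within the scatter) is too small to tell the two apart. For the measured compounds named here, compound 2 therefore stands level with compound 1 on the numbers so far, and neither can be called the stronger inhibitor.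

Compound 3, `CCc1ccc(Nc2ncnc3cc(OC)c(OCCCCC(=O)Nc4ccc(S(N)(=O)=O)cc4)cc23)cc1`, changes the same part of the molecule once more: 4-ethylphenyl in place of 3-methylphenyl on a nitrogen on an aromatic ring. Going by the values given here, the single measured step that bears on this place, the one from compound 1 to compound 2, lay within the scatter, so the numbers give no hint that changing this group moves the read-out of this assay in either direction. No step beyond the scatter is expected from compound 2 to compound 3, which means a 1.0-fold lower number from compound 2 to compound 3 (0.00 log units; within the scatter). Compound 3 is estimated to give 32000 nM in this assay, with a range from 15000 nM to 68000 nM.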

Compound 3, half-maximal inhibitory concentration: 10300 nM
For compound 3 the middle estimate is 3.1-fold (0.49 log units) above the measured one, and the stated range ends above it.
By their numbers in this assay, from the lowest: compound 3; then compounds 1 and 2 (each within the scatter of the next).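

The group on this nitrogen does move the read-out after all: in this assay there is a 3.1-fold lower number from compound 2 to compound 3 (0.49 log units; beyond the scatter), whereas the earlier swap gave only a 1.0-fold higher number from compound 1 to compound 2 (0.00 log units; within the scatter). For the compounds shown here, the cleanest view comes from the change of ethyl in place of chloro on an aromatic carbon, which gives a 3.1-fold lower number from compound 1 to compound 3 (0.49 log units; beyond the scatter), a modest step in which only that one group differs. So, among these three compounds, 4-ethylphenyl is the only group on this nitrogen whose number stands apart, while 4-chlorophenyl and 3-methylphenyl remain level, and no measurement at hand explains why the ethyl compound differs.

The step from 3-methylphenyl to 4-ethylphenyl changes both the group on the ring and where it is attached, so these compounds cannot show which of the two matters. Going by these compounds, it also remains open whether a 4-methylphenyl would give a number like that of compound 3, and whether a longer chain, as in 4-propylphenyl, or an amine on the ring would take the number lower still or bring it back up.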